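The source may hold more compounds than are shown below. What is called first, only, known or untested is meant among the compounds shown, and "the series" means these compounds.

The two measured compounds share a spirocyclic fragment and differ in what hangs from it. Compound 1 `CC1(C)C[C@]2(CC[C@H](c3nc(COc4ccc(-n5cnnn5)cc4)cs3)CC2)CO1` carries a thiazole linked to a tetrazolylphenyl ether, and in a functional assay on HEK293 cells for agonist activity at Glucose-dependent insulinotropic receptor (Homo sapiens), read by HTRF and cAMP accumulation, with a stated time of 30 min (on this read-out higher numbers stand for an effect only at larger amounts of compound and lower numbers for an effect already at smaller amounts), compound 1 gives 85 nM. Compound 2 `Cc1c(Nc2ccc(S(C)(=O)=O)cc2F)ncnc1O[C@H]1CC[C@]2(CC1)COC(C)(C)C2` instead presents an aminopyrimidine bearing a fluorinated phenyl with a methylsulfonyl group, and in this assay compound 2 gives 13 nM. Of the two numbers, compound 2 holds the lower one, and the gap to compound 1 lies beyond the usual scatter.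

Compound 3 `Cc1c(Nc2ccc(C(=O)N(C)C)cc2F)ncnc1O[C@H]1CC[C@]2(CC1)COC(C)(C)C2` keeps the whole framework of compound 2 and changes a single group: dimethylcarbamoyl in place of methylsulfonyl on an aromatic carbon. Among the measured compounds shown here, no measured pair in this set shows this particular exchange, so the direction of the step rests on the general weight of the change rather than on a precedent here.

The exchange is expected to cost little, with a step of a 2.3-fold higher number from compound 2 to compound 3 (0.36 log units; beyond the scatter) that may stay within the scatter or only just exceed it. Compound 3 is therefore estimated at 30 nM in this assay, with a range from 8 nM to 120 nM.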

Compound 3, half-maximal effective concentration: 33 nM
For compound 3 the middle estimate is 1.1-fold (0.04 log units) below the measured one; the measured number falls inside the stated range.
By their numbers in this assay, from the lowest: compound 2; then compound 3; then compound 1.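

Among the compounds shown here, exchanging methylsulfonyl for dimethylcarbamoyl on this aromatic carbon, meta to a fluoro group and para to a large group, gives a 2.5-fold higher number from compound 2 to compound 3 (0.40 log units; beyond the scatter) in this assay, and this is the first comparison in the set in which only one place differs. The step is modest, so this position accepts dimethylcarbamoyl with a limited shift in the read-out, although the number does respond to the group placed there and methylsulfonyl holds the lower number of this pair. Nothing measured here bears on why the two groups differ in this way.

The compounds shown leave open how other groups on this aromatic carbon would compare with methylsulfonyl and dimethylcarbamoyl, for example a nitrile, a carboxylic acid or a smaller amide such as the unsubstituted carboxamide. They also leave open what part the fluoro group plays, since it stays unchanged in compound 2 and compound 3, and whether replacing it with hydrogen or chlorine would alter the size of this step.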